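The compounds below may be only part of what the source reports. "The series", "measured", "known", "first", "only" and "open" are said of these compounds alone.

Measured compounds:
Compound 1, `C=CCCCCOc1ccccc1-c1cnc(OCCC=C)n1C`: 17000 nM
Compound 2, `C=CCCCCOc1ccc(OC)cc1-c1cnc(OCCC=C)n1C`: 62000 nM
Compound 3, `C=CCCCCOc1ncc(-c2ccccc2OC)n1C`: 13000 nM

These values come from a functional assay on SK-MEL-28 cells (Homo sapiens) for inhibition, read by colorimetric assay and MTT assay, with a stated time of 72 h; on this read-out lower numbers stand for stronger inhibition and higher numbers for weaker inhibition. Compound 1 and compound 2 differ in one place: methoxy in place of hydrogen on an aromatic carbon. That change gives a 3.6-fold higher number from compound 1 to compound 2 (0.56 log units; beyond the scatter). Compound 3 has the lowest number of the three; compound 3 and compound 1 lie within the scatter of each other, while compound 2 stands beyond the scatter from compound 3. The difference between the core of compound 1 and the core of compound 3 is not broken down here.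

Compound 4, `C=CCCCCOc1ncc(-c2cccc(OC)c2OC)n1C`, has not yet been measured in this assay. It differs from compound 3 in one place: methoxy in place of hydrogen on an aromatic carbon. Among the measured compounds shown here, this is the same kind of change as the one from compound 1 to compound 2, though the surroundings differ: in compound 2 the entering methoxy is meta to a large group and para to a (hex-5-en-1-yl)oxy group, whereas in compound 4 it is ortho to a methoxy group and meta to a large group. For the measured compounds named here, the earlier step, a 3.6-fold higher number from compound 1 to compound 2 (0.56 log units; beyond the scatter), lies beyond the scatter and is the only measured instance of this kind of change. On that basis compound 4 is expected to show a rise of roughly a 3.1-fold higher number from compound 3 to compound 4 (0.49 log units; beyond the scatter). Compound 4 is therefore estimated at 40000 nM, with a likely range from 15000 nM to 100000 nM.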

Compound 4, half-maximal inhibitory concentration: 27000 nM
Compound 4: the middle estimate sits 1.5-fold (0.17 log units) above what was measured; measured number inside the range.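

In this assay, methoxy in place of hydrogen on an aromatic carbon gives a 2.1-fold higher number from compound 3 to compound 4 (0.32 log units; beyond the scatter). The step runs the same way as the earlier one, and the two cannot be told apart in size: the same change on two cores in this assay, a 3.6-fold higher number (0.56 log units; beyond the scatter) from compound 1 to compound 2 and a 2.1-fold higher number (0.32 log units; beyond the scatter) from compound 3 to compound 4, 1.8-fold (0.24 log units) apart, within the scatter of two such steps So, across these two pairs, the change carries from one core to the other as a modest rise in the number, which means weaker inhibition, but two pairs do not establish a rule for the series, and they do not show what lies behind the rise or whether it depends on where the methoxy sits, given that in compound 4 it is ortho to a methoxy group and meta to a large group.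

Going by these compounds, it remains open whether an amine or a carboxylic acid at that place on the ring would raise the number as methoxy does. The compounds shown also leave open how a longer chain in place of the (hex-5-en-1-yl)oxy group would compare with compound 3 at 13000 nM.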